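Two Measured Analogues Point the Way to Compound 4

The source may report more compounds than this note shows. Statements on the series, on what has been measured and on what is new or still open speak of the compounds shown alone.

Compound 1 `NC1=NC2(CCSCC2)N(OCCCOc2cccc(Cl)c2)C(N)=N1`: 88.8%
Compound 2 `NC1=NC2(CCSCC2)N(OCCCOc2ccc(Br)cc2)C(N)=N1`: "not determined" (no result reported)
Compound 3 `COc1ccc(OCCCON2C(N)=NC(N)=NC23CCSCC3)cc1`: 86.6%

Three compounds sharing one core were examined in an assay on isolated protein for inhibition of Dihydrofolate reductase (Homo sapiens), read by spectrophotometry, using NADPH, with stated times of 5 s and 6 min, tested at 50 uM; a higher number here means a stronger effect of the compound at the concentration tested, a lower number a weaker effect. In this assay compound 1 gives 88.8%, and compound 3 gives 86.6%. For compound 2 no number was obtained, so the record shows only "not determined" (no result reported). For the measured compounds named here, compound 3 therefore stands lowest of the two numbers available, but its only neighbour is compound 1, and the step of a number 2.2 percentage points lower from compound 1 to compound 3 (within the scatter) lies within the scatter, so the two cannot be ordered.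

Compound 4 `NC1=NC2(CCSCC2)N(OCCCOc2ccccc2Cl)C(N)=N1` has not been measured. It differs from compound 3 in one place: 2-chlorophenyl in place of 4-methoxyphenyl on an oxygen on a saturated carbon. Going by the values given here, the only measured step that bears on this is the exchange of one aromatic substituent for another on the same oxygen, a number 2.2 percentage points lower from compound 1 to compound 3 (within the scatter), which was within the scatter. On that basis a further exchange of the aromatic group is expected to move this assay by little, with no direction favoured, and the expected step is a number 0.6 percentage points lower from compound 3 to compound 4 (within the scatter). Compound 4 is accordingly estimated to give 86%, with a likely range from 72% to 95%.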

Compound 4, a percentage reported as inhibition, at one concentration (the size of the read-out at that concentration, not a potency): 89.6%
Compound 4: middle estimate off by 3.6 percentage points, on the low side, and the stated range covers the measured number.
By their numbers in this assay, from the lowest: compounds 3, 1 and 4 (each within the scatter of the next).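

With compound 4, the position on an oxygen on a saturated carbon has now carried three different aromatic groups, and neither new step separates them in this assay (first a number 3 percentage points higher from compound 3 to compound 4 (within the scatter) and then a number 0.8 percentage points higher from compound 1 to compound 4 (within the scatter)). The earlier pair showed only that 4-methoxyphenyl and 3-chlorophenyl could not be told apart here; these steps add that 2-chlorophenyl cannot be told apart from either, even though it brings a chlorine in place of a group with one hydrogen-bond acceptor, and so compounds 1, 3 and 4 form a single group at the one concentration tested. Nothing available accounts for this lack of separation.

Going by these compounds, the read-out is taken at one concentration and is not a potency, so any differences among compounds 1, 3 and 4 that this measure does not resolve remain open, as does the place of compound 2, which has no number. Also open, on these data alone, is whether an amine or a carboxylic acid on the aromatic ring, or a longer chain at this position, would give a step beyond the scatter.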